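The compounds below may be only part of what the source reports. "The series", "measured", "known", "first", "only" and "open" are said of these compounds alone.

Compound 1, `CNC(=O)c1cc(Oc2ccc(NC(=O)c3cc(-c4ccc(C)cc4)ncn3)cc2)ccn1`: > 100000 nM
Compound 2, `CNC(=O)c1cc(Oc2ccc(NC(=O)c3cc(-c4ccc(C(F)(F)F)cc4)ncn3)cc2F)ccn1`: > 100000 nM

In a functional assay on PC-3 cells (Homo sapiens) for cytotoxicity, read by MTT assay, with a stated time of 72 h (a higher number here means a weaker inhibitor, a lower number a stronger inhibitor), compound 2 gives only a limit, > 100000 nM, not a number. It therefore stands at the limit of > 100000 nM in this assay, at which 2 of the 2 values shown sit. Compound 3, `CNC(=O)c1cc(Oc2ccc(NC(=O)c3cc(-c4ccc(C)cc4)ncn3)cc2F)ccn1`, differs from compound 2 by methyl in place of trifluoromethyl on an aromatic carbon. Among the compounds with values here, no measured step joins the two, so the size of the step in this assay cannot be read from the data; the expected step is a step that the limit leaves unreadable from compound 2 to compound 3, none beyond the scatter. Compound 1, which carries the same methyl, also reaches only its limit, > 100000 nM. Compound 3 is expected at about 150000 nM, between 50000 nM and 500000 nM.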

Compound 3, half-maximal inhibitory concentration: 40200 nM
For compound 3 the middle estimate is 3.7-fold (0.57 log units) above the measured one, outside the stated range (below it).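

In this assay, the change from 4-(trifluoromethyl)phenyl to 4-methylphenyl gives an at least 2.4-fold lower number from compound 2 to compound 3 (0.39 log units; beyond the scatter), so this position can affect the reading when the fluoro is present. Fluoro in place of hydrogen on an aromatic carbon gives an at least 2.4-fold lower number from compound 1 to compound 3 (0.39 log units; beyond the scatter), so among these compounds a number below the limit appears only with methyl and fluoro together. The true size of each step remains unknown, since each starts from a limit: the limit of > 100000 nM in this assay, at which 2 of the 3 values shown sit.

From the compounds shown here alone, it remains open how an amine, a carboxylic acid or a longer chain such as propyl would read at this position. Going by these compounds, whether any such group would give a lower number than compound 3 also remains open.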